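A few compounds are considered here, and "the series" means these few. Any claim that something is new, unique, unknown or untested is made for them only; others in the source may bear on it.

Compound 3 `O=C(CCCCC1CCSS1)NCc1cn(CCCCCOc2ccc3cc(-c4ccccc4)c(=O)oc3c2)nn1` stands lowest of the three numbers in a functional assay on PC-12 cells (Rattus norvegicus) for cytotoxicity, read by MTT assay, with stated times of 3 h and 2 h, tested at 50 uM (on this read-out higher numbers stand for a stronger effect at the one concentration tested and lower numbers for a weaker effect), giving 17.7%. Compound 2 `CCOC(=O)c1cc2ccc(OCCCCCn3cc(CNC(=O)CCCCC4CCSS4)nn3)cc2oc1=O` gives 40.7% and compound 1 `O=C(CCCCC1CCSS1)NCc1cn(CCCCCOc2ccc3ccc(=O)oc3c2)nn1` gives 84.9%. The steps at this aromatic carbon were all downward: a number 44.2 percentage points lower from compound 1 to compound 2 (beyond the scatter), a number 67.2 percentage points lower from compound 1 to compound 3 (beyond the scatter) and a number 23 percentage points lower from compound 2 to compound 3 (beyond the scatter). Compound 4 `COc1ccc(-c2cc3ccc(OCCCCCn4cc(CNC(=O)CCCCC5CCSS5)nn4)cc3oc2=O)cc1OC` differs from compound 3 by 3,4-dimethoxyphenyl in place of phenyl on an aromatic carbon. Among the measured compounds shown here, all three measured steps bear on it only in that larger groups at this position gave lower numbers, and they offer no step in which a phenyl itself carries substituents. With compound 3 already low, the step is expected to be small or within the scatter, a number 5.7 percentage points lower from compound 3 to compound 4 (within the scatter). Compound 4 is estimated at 12%, in the range 3% to 30%.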

Compound 4, a percentage reported as activity, at one concentration (the size of the read-out at that concentration, not a potency): 55%
Estimate against measurement, compound 4: 43 percentage points below, and the stated range ends below it.
By their numbers in this assay, from the lowest: compound 3; then compound 2; then compound 4; then compound 1.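

Substitution on the phenyl matters at this position: 3,4-dimethoxyphenyl lifts the lowest number of the series (a number 37.3 percentage points higher from compound 3 to compound 4 (beyond the scatter)). Group size alone therefore does not order these compounds, as 3,4-dimethoxyphenyl also stands above ethoxycarbonyl (a number 14.3 percentage points higher from compound 2 to compound 4 (beyond the scatter)), while hydrogen still stands above it (a number 29.9 percentage points lower from compound 1 to compound 4 (beyond the scatter)). Nothing available here explains the rise. As far as these compounds go, whether a single methoxy group on the phenyl would give the same rise remains open. So does whether a hydroxy group or an amine on the phenyl would behave like the two methoxy groups.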